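A few compounds are considered here, and "the series" means these few. Any claim that something is new, unique, unknown or untested is made for them only; others in the source may bear on it.

In an ADME assay on BAEC cells (Bos taurus) for cytotoxicity, read by MTT assay, with a stated time of 2 days (a lower number here means a stronger inhibitor, a higher number a weaker inhibitor), compound 1 (`COC1=C(Br)C(=O)[C@]2(C=C1)CO2`) gives 11000 nM. Compound 2 (`COC1=CC(=O)[C@]2(C=C1Br)CO2`) stands at > 22000 nM, which is a limit of the assay and not a number. Compound 3 (`COC1=CC(=O)[C@]2(C=C1)CO2`) has not yet been measured. It differs from compound 2 in one place: hydrogen in place of bromo on a double-bonded ring carbon. For the measured compounds named here, no step between measured compounds gauges this change, so in this assay no shift beyond the scatter is expected, and compound 3 should remain weak. The expected change is a step that the limit leaves unreadable from compound 2 to compound 3. The value estimated for compound 3 is 30000 nM, with an expected range of 12000 nM to 80000 nM.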

Compound 3, half-maximal inhibitory concentration: 33000 nM
Compound 3: the middle estimate sits 1.1-fold (0.04 log units) below what was measured, within the range that was stated.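

For compound 2 this assay gives only a limit, so the step to compound 3 at this position cannot be read: the limit of > 22000 nM in this assay, at which 1 of the 3 values shown sits. For the compounds shown here, compound 3 does, however, supply the first real number for the core without bromo. In this assay it shows that the bromo on the other double-bonded ring carbon, in compound 1, matters: hydrogen there gives a 3.0-fold higher number from compound 1 to compound 3 (0.48 log units; beyond the scatter). Going by these compounds, whether the bromo of compound 2 shifts the number at all remains open. So does how a chloro group or an amine would read on either ring carbon.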